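The source may hold more compounds than are shown below. What is called first, only, known or untested is meant among the compounds shown, and "the series" means these compounds.

Measured so far in an in vitro functional assay on CHO/Galpha16 cells for antagonist activity at C-C chemokine receptor type 8 (Homo sapiens), read by FLIPR; on this read-out lower numbers stand for stronger inhibition and higher numbers for weaker inhibition:
- compound 1 `CCCC(=O)N1CCC(NS(=O)(=O)c2ccc(NC(=O)C(CC)CC)c3ccccc23)CC1` gives 639 nM
- compound 2 `CCCCc1ccc(C(=O)Nc2ccc(S(=O)(=O)NC3CCN(C(=O)CCC)CC3)c3ccccc23)cc1` gives 15.3 nM

Compound 2 has the lowest number of the two in this assay; compound 1 sits well above it, and the gap is beyond the scatter. Going by the values given here, the one step in hand, a 42-fold lower number from compound 1 to compound 2 (1.62 log units; beyond the scatter), shows that the group on the carbonyl carbon of the amide on the shared core moves the read-out strongly.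

Compound 3 `CCCC(=O)N1CCC(NS(=O)(=O)c2ccc(NC(=O)c3ccoc3)c3ccccc23)CC1` is the next change at that position: furan-3-yl in place of 4-butylphenyl on a carbonyl carbon. Among the compounds with values here, no measured pair covers an aromatic ring of this kind at that place, so the only guide is the step from compound 1 to compound 2, which is large. Since the 4-butylphenyl that carried compound 2 to its low number is removed, the expectation is a move back toward compound 1 rather than further down, though a smaller aromatic group need not lose all of that ground. The step from compound 2 to compound 3 in this assay is therefore expected to be upward, a 9.8-fold higher number from compound 2 to compound 3 (0.99 log units; beyond the scatter). For compound 3 the estimate in this assay is 150 nM, with a range from 40 nM to 600 nM.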

Compound 3, half-maximal inhibitory concentration: 1520 nM
The estimate for compound 3 lay 10-fold (1.01 log units) below the measured number; measured number above the stated range.
By their numbers in this assay, from the lowest: compound 2; then compound 1; then compound 3.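

In this assay, furan-3-yl in place of 4-butylphenyl on the carbonyl carbon gives up everything gained earlier at this position: a 99-fold higher number from compound 2 to compound 3 (2.00 log units; beyond the scatter). An aromatic ring at this place is therefore not enough for a low number, as furan-3-yl does not even match the open-chain pentan-3-yl, with a 2.4-fold higher number from compound 1 to compound 3 (0.38 log units; beyond the scatter), a modest step but one beyond the scatter. Of the three groups seen here, only 4-butylphenyl gives a low number, so the earlier gain belongs to that group as a whole and not to aromatic character as such. No measurement at hand speaks to the reason for these differences.

The compounds shown leave open whether the butyl chain or the six-membered carbon ring accounts for the low number of compound 2, and an unsubstituted phenyl at the same carbonyl carbon would begin to separate the two. They also leave open how far the read-out depends on the chain itself, which a shorter chain such as ethyl or a longer one such as hexyl on the phenyl ring would address.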